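The compounds below may be only part of what the source reports. "The series", "measured", "known", "first", "only" and "open" are said of these compounds alone.

Going by the values given here, compound 3 `O=C(/C=C/c1ccc2c(c1)B(O)OC2)c1ccc(I)cc1` stands with the highest of the three numbers measured so far in a functional assay on HCT-116 cells (Homo sapiens) for cytotoxicity, read by MTT assay, with a stated time of 48 h; a lower number here means a stronger inhibitor, a higher number a weaker inhibitor: compound 3 gives 11600 nM. Its nearest neighbour is compound 1 `O=C(/C=C/c1ccc2c(c1)B(O)OC2)c1ccccc1`, which gives 6100 nM; the step of a 1.9-fold higher number from compound 1 to compound 3 (0.28 log units; within the scatter) lies within the scatter. Furthest is compound 2 `O=C(/C=C/c1ccc2c(c1)B(O)OC2)c1ccc(F)cc1`, which gives 2800 nM; the step of a 4.1-fold higher number from compound 2 to compound 3 (0.62 log units; beyond the scatter) is modest but beyond the scatter, as is a 2.2-fold lower number from compound 1 to compound 2 (0.34 log units; beyond the scatter). Compound 4 `CSc1ccc(C(=O)/C=C/c2ccc3c(c2)B(O)OC3)cc1` differs from compound 3 by methylsulfanyl in place of iodo on an aromatic carbon. Among the compounds with values here, no measured step exchanges a halogen for a group of this kind; the three steps that bear on it all change the same aromatic carbon, and none of them moved the number by more than a modest amount. Compound 4 is therefore expected to land near compound 1 and compound 3 rather than far from them. The step of a 1.7-fold lower number from compound 3 to compound 4 (0.22 log units; within the scatter) is expected to stay within or close to the scatter, in the direction of a somewhat lower number. The estimate for compound 4 is 7000 nM, with a range from 2500 nM to 20000 nM.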

Compound 4, half-maximal inhibitory concentration: 10300 nM
The estimate for compound 4 lay 1.5-fold (0.17 log units) below the measured number; low and high end bracket the measured number.
By their numbers in this assay, from the lowest: compound 2; then compounds 1, 4 and 3 (each within the scatter of the next).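

In this assay, methylsulfanyl on this aromatic carbon, para to a large group, gives a number that cannot be told apart from that with iodo (a 1.1-fold lower number from compound 3 to compound 4 (0.05 log units; within the scatter)) or with hydrogen (a 1.7-fold higher number from compound 1 to compound 4 (0.23 log units; within the scatter)). Fluoro remains the only one of the four groups shown that stands apart from the others, and the step from it to the sulfur-bearing group is modest but beyond the scatter (a 3.7-fold higher number from compound 2 to compound 4 (0.57 log units; beyond the scatter)). Nothing available here bears on why fluoro alone separates from the other three groups.

The compounds shown leave open whether an amine, a carboxylic acid or a methoxy group on this carbon would stay with compounds 1, 3 and 4 or join compound 2. They also leave open whether chloro would behave like fluoro or like iodo.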